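Amide change at the carbonyl, compound 3 to compound 4

This account rests on a few compounds, and the source may have more. Where it says the series, first, only, none or still open, it means among the compounds named here.

Values so far in a functional assay on Huh-5-2 cells (Homo sapiens), read by MTT assay; on this read-out higher numbers stand for lower toxicity in this test and lower numbers for higher toxicity in this test
compound 1 `O=C(O)c1ccc2c(c1)nc(-c1ccc(OCc3ccccc3-c3ccc(Cl)cc3)cc1)n2C1CCCCC1` gives 25000 nM
compound 2 `CCCNC(=O)c1ccc(-c2ccc(Cl)cc2)c(COc2ccc(-c3nc4cc(C(=O)O)ccc4n3C3CCCCC3)c(F)c2)c1` gives 24000 nM
compound 3 `O=C(O)c1ccc2c(c1)nc(-c1ccc(OCc3cc(C(=O)NCCO)ccc3-c3ccc(Cl)cc3)cc1F)n2C1CCCCC1` gives 26000 nM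

In this assay compound 3 stands level with compound 1 and compound 2, all three values lying within the usual scatter of one another. The next compound is compound 4 `O=C(O)c1ccc2c(c1)nc(-c1ccc(OCc3cc(C(=O)N4CCCCC4)ccc3-c3ccc(Cl)cc3)cc1F)n2C1CCCCC1`, and the change is piperidin-1-yl in place of (2-hydroxyethyl)amino on a carbonyl carbon. For the measured compounds named here, one measured step bears on this amide: a 1.1-fold higher number from compound 2 to compound 3 (0.03 log units; within the scatter), a change within the scatter. Compound 1, which has no such amide, gives 25000 nM in the same range. Going by the values given here, no measured compound carries a ring on this carbonyl carbon, so the evidence for piperidin-1-yl is indirect. No step beyond the scatter is therefore expected in this assay for this change. The estimated step is a 1.1-fold lower number from compound 3 to compound 4 (0.05 log units; within the scatter) with no firm direction. For compound 4 the estimated value is 23000 nM, with an expected range from 12000 nM to 45000 nM.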

Compound 4, half-maximal cytotoxic concentration: 24000 nM
The estimate for compound 4 lay 1.0-fold (0.02 log units) below the measured number; measured number inside the range.
By their numbers in this assay, from the lowest: compounds 2, 4, 1 and 3 (each within the scatter of the next).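

In this assay, a ring on this carbonyl carbon now has a direct reading: piperidin-1-yl in place of (2-hydroxyethyl)amino gives a 1.1-fold lower number from compound 3 to compound 4 (0.03 log units; within the scatter), and piperidin-1-yl in place of propylamino gives no change at the digits printed from compound 2 to compound 4 (within the scatter). Compound 4 carries neither the amide hydrogen nor the hydroxy group, yet the three amides at this position, compounds 2, 3 and 4, show no step beyond the scatter. Nothing measured here offers an explanation for this flat reading.

Still open, on these data alone, is whether any group on this carbonyl carbon moves the number beyond the scatter, for instance a chain ending in an amine or a chain ending in a carboxylic acid. Morpholin-4-yl would show whether a ring oxygen changes the picture set by piperidin-1-yl.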